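A 2,6-difluorobenzyl swap in a narrow series

This account rests on a few compounds, and the source may have more. Where it says the series, first, only, none or still open, it means among the compounds named here.

In a functional assay on HCT-116 cells (Homo sapiens) for inhibition, read by MTT assay, with a stated time of 48 h (a higher number here means a weaker inhibitor, a lower number a stronger inhibitor), compound 1 (`Clc1ccccc1CSc1nnc(-c2ccncc2)n1-c1ccccc1`) gives 13900 nM while compound 2 (`Clc1cccc(CSc2nnc(-c3ccncc3)n2-c2ccccc2)c1`) gives 9820 nM and compound 3 (`Brc1ccc(CSc2nnc(-c3ccncc3)n2-c2ccccc2)cc1`) gives 11100 nM on the same read-out. Compound 3 is not set apart from either of the others, with a 1.1-fold higher number from compound 2 to compound 3 (0.05 log units; within the scatter) and a 1.3-fold lower number from compound 1 to compound 3 (0.10 log units; within the scatter) as the two steps that reach it.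

Compound 4 (`Fc1cccc(F)c1CSc1nnc(-c2ccncc2)n1-c1ccccc1`) has not yet been measured. It carries 2,6-difluorophenyl in place of 4-bromophenyl on a saturated chain carbon bound to a sulfur. All three measured steps changed the group at this same place, and the remaining one, a 1.4-fold lower number from compound 1 to compound 2 (0.15 log units; within the scatter) as well, stays inside the scatter like the other two. Going by the values given here, none of the measured compounds carries fluorine, however, so the data do not directly cover the entering group. The estimated move in this assay is a 1.0-fold higher number from compound 3 to compound 4 (0.02 log units; within the scatter) and so no step beyond the scatter is expected. For compound 4 the expected value is 11500 nM with an estimated range of 6000 nM to 22000 nM in this assay.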

Compound 4, half-maximal inhibitory concentration: 22100 nM
Beside the measured number, compound 4's estimate is 1.9-fold (0.28 log units) below it; measured number above the stated range.
By their numbers in this assay, from the lowest: compounds 2, 3, 1 and 4 (each within the scatter of the next, the first and the last beyond it).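

In this assay, going by these compounds alone, 2,6-difluorophenyl gives the first step at this place, on a saturated chain carbon bound to a sulfur, that passes the scatter, though only modestly: a 2.3-fold higher number from compound 2 to compound 4 (0.35 log units; beyond the scatter). The other two steps stay inside the scatter, a 2.0-fold higher number from compound 3 to compound 4 (0.30 log units; within the scatter) and a 1.6-fold higher number from compound 1 to compound 4 (0.20 log units; within the scatter), so all four substituted benzyl groups lie in a narrow band and only compound 2 and compound 4 are told apart. No measurement shown explains why this one pair separates.

The compounds shown vary only halogens on the phenyl and keep the shared core fixed, so they leave open whether a methoxy group or an amine on that phenyl, or a longer chain at this place, would move the number further. Nor do they tell whether a single fluorine on the phenyl would read like compound 4 or like the other three.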